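The source may report more compounds than this note shows. Statements on the series, on what has been measured and on what is new or still open speak of the compounds shown alone.

Measured compounds:
compound 1, `CN1CCN(C(=O)/C=C/c2ccncc2-c2ccc3ccccc3c2)CC1`, gives 101%
compound 2, `CNC(=O)/C=C/c1ccncc1-c1ccc2cccnc2c1`, gives 82%

Both compounds were tested in an assay on a protein complex for inhibition of CDK8/Cyclin C (Homo sapiens), with a stated time of 1 h, tested at 10 uM; on this read-out higher numbers stand for more inhibition at the one concentration tested (going by the name of the read-out) and lower numbers for less inhibition. Compound 1 stands highest of the two numbers with 101%, and compound 2 gives 82%. Compound 2 sits a little under compound 1, by a gap that lies beyond the usual scatter. For the measured compounds named here, the two compounds differ in more than one place, so no single step links them.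

Compound 3, `O=C(O)[C@@H]1CCCN1C(=O)/C=C/c1ccncc1-c1ccc2ccccc2c1`, has not yet been measured. It keeps the core of compound 1 and changes one group on the carbonyl carbon: 2-carboxypyrrolidin-1-yl in place of 4-methylpiperazin-1-yl on a carbonyl carbon. Since compound 1 already reaches close to the top of the scale in this assay, there is little room for an increase, and a move downward is the more likely direction, expected to be modest. The expected step from compound 1 to compound 3 is a number 16 percentage points lower from compound 1 to compound 3 (beyond the scatter). Compound 3 is therefore estimated at 85%, in a range from 55% to 100%.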

Compound 3, a percentage reported as inhibition, at one concentration (the size of the read-out at that concentration, not a potency): 67%
Compound 3: the middle estimate sits 18 percentage points above what was measured, within the range that was stated.
By their numbers in this assay, from the lowest: compound 3; then compound 2; then compound 1.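

In this assay, the group on the carbonyl carbon clearly matters: 2-carboxypyrrolidin-1-yl in place of 4-methylpiperazin-1-yl gives a number 34 percentage points lower from compound 1 to compound 3 (beyond the scatter). For the compounds shown here, this is the first single change that can be read, since the earlier pair differed in more than one place. Even so, compound 3 still gives 67%, so inhibition at the one concentration tested is reduced but not lost with this group in place.

Still open, going by these compounds, is whether the drop goes with the carboxylic acid or with the five-membered ring, a question that plain pyrrolidin-1-yl on the same carbonyl carbon could help to separate. Nothing available here bears on why the number falls.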